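The compounds below may be only part of what the source reports. "The series", "measured", "known", "first", "only" and "open" are said of these compounds alone.

Measured so far in a functional assay on HCT-116 cells (Homo sapiens) for inhibition, read by sulforhodamine B assay, with a stated time of 48 h, tested at 50 uM; a lower number here means less inhibition of growth, a higher number more inhibition of growth at the concentration tested:

Compound 1, `COc1ccc(/C=C/C(=O)/C=C/c2ccc(OCc3cn(CCCCCOc4cc(=O)oc5ccccc45)nn3)c(OC)c2)cc1`: 35%
Compound 2, `COc1cc(/C=C/C(=O)/C=C/c2cc(OC)c(OC)c(OC)c2)ccc1OCc1cn(CCOc2cc(=O)oc3ccccc23)nn1`: 89%
Compound 3, `COc1cc(/C=C/C(=O)/C=C/c2cc(OC)c(OC)c(OC)c2)ccc1OCc1cn(CCCOc2cc(=O)oc3ccccc23)nn1`: 76%

Compound 1 stands lowest of the three in this assay; compound 3 lies well above it, beyond the usual scatter, and compound 2 lies higher still. Compound 4, `COc1cc(/C=C/C(=O)/C=C/c2ccccc2)ccc1OCc1cn(CCCCCOc2cc(=O)oc3ccccc23)nn1`, has not yet been measured. It differs from compound 1 in one place: hydrogen in place of methoxy on an aromatic carbon.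

Among the measured compounds shown here, no measured pair here shows what this change does on its own, so any expectation rests on compound 1 alone. The step of a number 8 percentage points lower from compound 1 to compound 4 (within the scatter) is expected to be small, either downward or within the scatter, since a hydrogen in place of methoxy takes compound 4 further from the more substituted rings of compounds 2 and 3. Compound 4 is expected to give 27%, within a range from 8% to 48%.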

Compound 4, percent growth inhibition at one concentration: 24%
Compound 4: middle estimate off by 3 percentage points, on the high side; low and high end bracket the measured number.
By their numbers in this assay, from the lowest: compound 4; then compound 1; then compound 3; then compound 2.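

Putting hydrogen in place of methoxy, which turns 4-methoxyphenyl into phenyl, gives in this assay a number 11 percentage points lower from compound 1 to compound 4 (beyond the scatter). Among the compounds shown here, this is the first direct reading of this position: on the core of compound 1, methoxy goes with modestly more inhibition of growth than hydrogen does. No measurement at hand explains why this step occurs.

Still open, from the compounds shown here alone, is how other groups at this place, such as hydroxyl, fluorine or an amine, would compare with methoxy. Also open, going by these compounds, is whether the same change would give a similar step with a longer chain.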